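A few compounds are considered here, and "the series" means these few. Any claim that something is new, unique, unknown or untested is made for them only; others in the source may bear on it.

Measured compounds and values

Compound 1 `Cc1ccc2c(c1)C1(C(=O)N2Cc2ccccc2)C(C#N)=C(N)Oc2cc3oc(-c4ccccc4)cc(=O)c3c(O)c21`: in a functional assay on A549 cells (Homo sapiens) for antiproliferative activity, read by MTT assay, with a stated time of 48 h (on this read-out lower numbers stand for stronger inhibition and higher numbers for weaker inhibition), compound 1 gives > 50000 nM, which is a limit of the assay and not a number.
Compound 2 `Cc1cccc2c1N(Cc1ccccc1)C(=O)C21C(C#N)=C(N)Oc2cc3oc(-c4ccccc4)cc(=O)c3c(O)c21`: in this assay compound 2 gives > 50000 nM, again a limit of the assay.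
Compound 3 `CCN1C(=O)C2(C(C#N)=C(N)Oc3cc4oc(-c5ccccc5)cc(=O)c4c(O)c32)c2cccc(C)c21`: in this assay compound 3 gives > 50000 nM, also a limit of the assay.

Going by the values given here, all three values sit at the same limit (the limit of > 50000 nM in this assay, at which 3 of the 3 values shown sit), so no compound is separated from another and no order can be read among them.

The change from compound 2 to compound 3 is methyl in place of phenyl on a saturated chain carbon bound to an amide-type nitrogen in a ring. Its step is a step that the two limits leave unreadable from compound 2 to compound 3.

Compound 1 and compound 2 have the same atoms joined differently; how the two cores differ is not broken down here.

Compound 4 `CCN1C(=O)C2(C(C#N)=C(N)Oc3cc4oc(-c5ccccc5)cc(=O)c4c(O)c32)c2cc(C)ccc21` is not yet measured. It differs from compound 1 by methyl in place of phenyl on a saturated chain carbon bound to an amide-type nitrogen in a ring, the same change that leads from compound 2 to compound 3, at the same place. Since both of those compounds sit at the limit and the step stays unreadable, compound 4 is expected to sit at the limit as well, with the expected step being a step that the limit leaves unreadable from compound 1 to compound 4.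

The estimate for compound 4 in this assay is 80000 nM, expected to fall between 30000 nM and 300000 nM.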

Compound 4, half-maximal inhibitory concentration: > 50000 nM
Compound 4 gave a limit, no number (the forecaster's own chance of this, stated with the estimate: 85%); the middle value does not contradict the limit.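

Compound 4 gives > 50000 nM in this assay, a limit of the assay and not a number. No step can be read between compound 1 and compound 4, or from benzyl to ethyl, as the series sits at one limit: the limit of > 50000 nM in this assay, at which 4 of the 4 values shown sit. The compounds shown leave open what separates them in activity, as none gives a number.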